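A few compounds are considered here, and "the series" means these few. Any claim that something is new, unique, unknown or untested is made for them only; others in the source may bear on it.

Working notes on the series. In a functional assay on TK-10 cells (Homo sapiens) for inhibition, read by sulforhodamine B assay, with a stated time of 48 h (a higher number here means a weaker inhibitor of growth, a lower number a stronger inhibitor of growth), compound 2 `COc1cc(-c2nn(-c3cccc(NC(=O)Nc4cc(C(F)(F)F)cc(C(F)(F)F)c4)c3)cc2-c2ccncc2)ccc1Cl` gives 2480 nM, the only numerical result in the set so far. Compound 1 `O=C(Nc1cccc(-n2cc(-c3ccncc3)c(-c3ccc(Cl)c(O)c3)n2)c1)Nc1cccc(C(F)(F)F)c1` returns only a limit in this assay, > 32500 nM, so its true value is not known (the limit of > 32500 nM in this assay, at which 1 of the 2 values shown sits). Compound 3 `O=C(Nc1cccc(-n2cc(-c3ccncc3)c(-c3ccc(Cl)c(O)c3)n2)c1)Nc1cc(C(F)(F)F)cc(C(F)(F)F)c1` is the next member: relative to compound 2 the change is hydrogen in place of methyl on an oxygen on an aromatic ring. The step from compound 2 to compound 3 is expected to go toward weaker growth inhibition, with compound 1 and its limit > 32500 nM as the only hint of direction; the estimated step is a 3.2-fold higher number from compound 2 to compound 3 (0.51 log units; beyond the scatter). For compound 3 the estimate in this assay is 8000 nM, within 2500 nM to 32500 nM, with a fair chance that only a limit is reported.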

Compound 3, concentration for total growth inhibition: 3580 nM
For compound 3 the middle estimate is 2.2-fold (0.35 log units) above the measured one; the measured number falls inside the stated range.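

In this assay, the change from 4-chloro-3-methoxyphenyl to 4-chloro-3-hydroxyphenyl leaves growth inhibition within the scatter, with a 1.4-fold higher number from compound 2 to compound 3 (0.16 log units; within the scatter). With the hydroxy group held constant, the added trifluoromethyl gives an at least 9.0-fold lower number from compound 1 to compound 3 (0.95 log units; beyond the scatter). The value for compound 1 is a limit, not a number: the limit of > 32500 nM in this assay, at which 1 of the 3 values shown sits.

As far as these compounds go, whether ethoxy or an amine at this place would also hold growth inhibition remains open. From the compounds shown here alone, the full size of the trifluoromethyl step, and whether it carries over to the methoxy compounds, also remains open.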